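The source may report more compounds than this note shows. Statements on the series, on what has been measured and on what is new or still open speak of the compounds shown alone.

Compound 1 `O=C(NCCCCc1ccccc1)n1ncc2ccccc21` is the outlier among the three measured compounds: in an assay on HEK293 cells for inhibition of acid ceramidase (Homo sapiens), read by fluorescence, with stated times of 30 min and 1 h (on this read-out lower numbers stand for stronger inhibition and higher numbers for weaker inhibition), compound 1 gives 4.7 nM. Compound 2 `Cc1ccccc1CNC(=O)n1cnc2ccccc21` gives 55.9 nM. Compound 3 `Cc1ccccc1CNC(=O)n1c(N)nc2ccccc21` carries an amino group where compound 2 carries hydrogen, and compound 3 gives 68.4 nM. Among the compounds with values here, the only single change that can be followed is a 1.2-fold higher number from compound 2 to compound 3 (0.09 log units; within the scatter), which is within the scatter. Compound 3 therefore holds the highest of the three numbers, indistinguishable from compound 2, while compound 1 sits well apart at the low end, a gap that is beyond the scatter.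

Compound 4 `CCCCCCNC(=O)n1c(N)nc2ccccc21` differs from compound 3 in one place: pentyl in place of 2-methylphenyl on a saturated chain carbon bound to an amide-type nitrogen. Within the data shown here, no measured step touches this position, since the step from compound 2 to compound 3 concerns only the amino group, and compound 1 differs from the others in more than one respect. The expectation for compound 4 therefore rests on little evidence, and no shift beyond the scatter is assumed. Compound 4 is estimated to give 50 nM, with a range from 15 nM to 170 nM. This expected outcome corresponds to a 1.4-fold lower number from compound 3 to compound 4 (0.14 log units; within the scatter).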

Compound 4, half-maximal inhibitory concentration: 2.4 nM
The estimate for compound 4 lay 21-fold (1.32 log units) above the measured number; the measured number lies below the stated range.
By their numbers in this assay, from the lowest: compounds 4 and 1 (each within the scatter of the next); then compounds 2 and 3 (each within the scatter of the next).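

In this assay the position on a saturated chain carbon bound to an amide-type nitrogen proves highly sensitive: pentyl in place of 2-methylphenyl gives a 29-fold lower number from compound 3 to compound 4 (1.45 log units; beyond the scatter) at this site. The only earlier single change, a 1.2-fold higher number from compound 2 to compound 3 (0.09 log units; within the scatter) on exchanging hydrogen for amino, did not show this, so compound 4 gives the first evidence among these compounds that a change at one place can move the number beyond the scatter, and here the aromatic ring leaves and a chain without a ring enters. Nothing available accounts for the size of this step.

Within the data shown here, the single exchange changes both the presence of the ring and the number of heavy atoms, so it remains open whether a cyclohexyl group, a benzyl group or a longer chain such as octyl at this position would give a number like that of compound 4 or like that of compound 3. From the compounds shown here alone, it also remains open whether the amino group would still make no difference beyond the scatter with pentyl in place of 2-methylphenyl, since its step has been read only with the latter group.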